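A Carboxymethoxy Group Replaces Fluoro on the Shared Core

A few compounds are considered here, and "the series" means these few. Any claim that something is new, unique, unknown or untested is made for them only; others in the source may bear on it.

In a functional assay on the whole organism for inhibition, with Rattus norvegicus as the target (on this read-out higher numbers stand for weaker inhibition and lower numbers for stronger inhibition), compound 1 (`O=C1ON=C(c2cccs2)/C1=C/c1cccs1`) gives 3700 nM and compound 2 (`O=C1ON=C(c2cccs2)/C1=C/c1ccc(F)cc1`) gives 4800 nM in the same test. Compound 2 therefore stands level with compound 1, as these two values lie within the usual scatter of repeated measurements and cannot be ranked.

Compound 3 (`O=C(O)COc1ccc(/C=C2\C(=O)ON=C2c2cccs2)cc1`) has not yet been measured. It keeps the shared core of compound 2, but carboxymethoxy stands in place of fluoro on an aromatic carbon (carboxymethoxy in place of fluoro on an aromatic carbon) of a six-membered aromatic ring of carbon only, para to a large group.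

Among the measured compounds shown here, no measured pair shows what a change at this place does, so any forecast here is uncertain. For the measured compounds named here, the two values so far offer only a narrow starting point and no trend to extend. The expected change in this assay is a 2.1-fold higher number from compound 2 to compound 3 (0.32 log units; beyond the scatter) towards weaker inhibition, a modest step. For compound 3 the estimated value is 10000 nM with an expected range from 2500 nM to 40000 nM on present evidence.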

Compound 3, half-maximal inhibitory concentration: 100000 nM
Compound 3: the middle estimate sits 10-fold (1.00 log units) below what was measured; measured number outside the range, above it.
By their numbers in this assay, from the lowest: compounds 1 and 2 (each within the scatter of the next); then compound 3.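

In this assay, putting carboxymethoxy in place of fluoro on an aromatic carbon, para to a large group, gives a 21-fold higher number from compound 2 to compound 3 (1.32 log units; beyond the scatter), a large step towards weaker inhibition. Among the compounds shown here, this is the first measured sign that the group at this place matters: the position does not accept every substituent equally, and this one goes with a clear loss of inhibition. The change brings several differences at once, since five heavy atoms replace one and a hydrogen-bond donor and two hydrogen-bond acceptors enter where fluoro counted none, and no measurement at hand explains the loss or says which of these differences counts.

For the compounds shown here, with only this single step at the position, it remains open whether the loss follows from the carboxylic acid end of the new group, from the length of the chain, or from the oxygen attached to the ring. A plain methoxy group at the same place, or an amine at the end of the same chain, would help to separate these possibilities.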